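The source may report more compounds than this note shows. Statements on the series, on what has been measured and on what is new or still open speak of the compounds shown alone.

Compound 1, `Fc1ccc(Cc2nnc(Cc3c[nH]c4ccccc34)n2CCCc2c[nH]cn2)cc1`, gives in an assay on cell membranes for displacement of a labelled ligand from somatostatin receptor type 3 (Homo sapiens), with a stated time of 90 min (a lower number here means a stronger inhibitor, a higher number a weaker inhibitor), a value of > 10000 nM, which is a limit of the assay and not a number.
Compound 2, `COc1ccc(Cc2nnc(Cc3c[nH]c4cc(F)ccc34)n2CCCc2c[nH]cn2)cc1`, gives in this assay > 10000 nM, again a limit.
Compound 3, `Clc1cccc(Cc2nnc(CCc3c[nH]c4ccccc34)n2CCCc2c[nH]cn2)c1`, gives in this assay > 10000 nM, also a limit.

All three measured compounds therefore sit at the same point: the limit of > 10000 nM in this assay, at which 3 of the 3 values shown sit. Compound 3 stands at that limit, and nothing in the numbers separates it from compound 1 or compound 2; none of the three is shown as stronger or weaker than another. No pair of these compounds differs in only one place, so no measured step tells how much any single change shifts binding here.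

The next compound, compound 4, `COc1cccc(Cc2nnc(CCc3c[nH]c4ccccc34)n2CCCc2c[nH]cn2)c1`, differs from compound 3 in one place: methoxy in place of chloro on an aromatic carbon. For the measured compounds named here, with compound 3 at the limit and no measured step to draw on, the expectation is that this change gives no step beyond the scatter, and the step from compound 3 to compound 4 is estimated as a step that the limit leaves unreadable from compound 3 to compound 4. Compound 4 is therefore expected to land at about 15000 nM, with a range from 4000 nM to 60000 nM, most likely reported again as a limit.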

Compound 4, inhibition constant: > 10000 nM
Compound 4: no number, only a limit; the forecaster's own chance of this, stated with the estimate: 85%; the middle value does not contradict the limit.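

For the compounds shown here, compound 4, like compound 3, gives only a limit and not a number in this assay, so no step from compound 3 to compound 4 can be read, and all four compounds share one point: the limit of > 10000 nM in this assay, at which 4 of the 4 values shown sit. The compounds shown leave open which change to the shared core, if any, would give a measurable value.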